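Cinnamoyl to thiophenesulfonyl on the serine-type amide series

The source may report more compounds than this note shows. Statements on the series, on what has been measured and on what is new or still open speak of the compounds shown alone.

Among the measured compounds shown here, compound 2 `CCCCCCCCCCCCCCCCCCNC(=O)[C@@H](NC(=O)/C=C/c1ccccc1)[C@@H](C)O` holds the only numeric value in a functional assay on HepG2 cells (Homo sapiens) for cytotoxicity, read by MTT assay, with a stated time of 48 h (on this read-out lower numbers stand for stronger inhibition and higher numbers for weaker inhibition), giving 128000 nM; compound 1 `CCCCCCCCCCCCCCCCCCNC(=O)[C@@H](NC(=O)c1ccccc1)[C@@H](C)O` sits at a limit of this assay, > 400000 nM. For the measured compounds named here, the one measured step, an at least 3.1-fold lower number from compound 1 to compound 2 (0.49 log units; beyond the scatter), shows that the acyl group on the amine nitrogen moves the number. Compound 3 `CCCCCCCCCCCCCCCCCCNC(=O)[C@@H](NS(=O)(=O)c1cccs1)[C@@H](C)O` differs from compound 2 by (thiophen-2-yl)sulfonyl in place of (2-phenylethenyl)carbonyl on an amine nitrogen. Going by the values given here, since compound 2 carries the only group seen to push the number down, removing it is expected to give a step back toward weaker inhibition, a 2.3-fold higher number from compound 2 to compound 3 (0.37 log units; beyond the scatter), with a fair chance of another limit. Compound 3 is estimated at 300000 nM, range 100000 nM to 1000000 nM.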

Compound 3, half-maximal inhibitory concentration: > 200000 nM
Compound 3 ended at the assay's limit; the forecaster's own chance of this, stated with the estimate: 50%; the middle value is on the limit's open side.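

In this assay compound 3 gives > 200000 nM, which is a limit of the assay and not a number. The (thiophen-2-yl)sulfonyl group on the amine nitrogen gives an at least 1.5-fold higher number from compound 2 to compound 3 (0.19 log units; that floor lies within the scatter), so this change is not shown to weaken inhibition beyond the scatter, although no value below the limit was reached. The step between the benzoyl and sulfonyl compounds cannot be read, as both are limits.

Open, on these data alone, is where compound 3 lies beyond its limit. Also open, as far as these compounds go, is whether a phenylsulfonyl group on the amine nitrogen would give a readable number.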